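The source may hold more compounds than are shown below. What is called first, only, known or untested is meant among the compounds shown, and "the series" means these compounds.

Measured compounds:
compound 1 `C#CCNC1CCc2c(OCCc3cc(NC(C)=O)ccc3Cl)cccc21`; in an assay on cells for inhibition of Amine oxidase [flavin-containing] B (Homo sapiens), read by fluorescence and Amplex Red, with stated times of 30 min and 15 min (on this read-out lower numbers stand for stronger inhibition and higher numbers for weaker inhibition), compound 1 gives 590 nM.
compound 2 `C#CCNC1CCc2c(OCCc3cc(NC(=O)C(C)(C)C)ccc3F)cccc21`; in this assay compound 2 gives only a limit of the assay, > 20000 nM.

Within the data shown here, compound 1 carries the only numerical value in the set; the other entry is a limit, (the limit of > 20000 nM in this assay, at which 1 of the 2 values shown sits). Compound 3 `C#CCNC1CCc2c(OCCc3cc(NC(=O)c4ccc(Cl)cc4)ccc3Cl)cccc21` differs from compound 1 by 4-chlorophenyl in place of methyl on a carbonyl carbon, acetyl to (4-chlorophenyl)carbonyl. Among the measured compounds shown here, no step between measured compounds is available to calibrate this change. For compound 3 a step beyond the scatter toward weaker inhibition is expected, a 5.1-fold higher number from compound 1 to compound 3 (0.71 log units; beyond the scatter). Compound 3 is accordingly estimated at 3000 nM, with a range of 500 nM to 20000 nM.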

Compound 3, half-maximal inhibitory concentration: > 20000 nM
Compound 3 ended at the assay's limit (the forecaster's own chance of this, stated with the estimate: 25%); at least 6.6-fold (0.82 log units) between middle value and limit.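

On the carbonyl carbon of the acetamido group, 4-chlorophenyl in place of methyl gives, in this assay, an at least 33-fold higher number from compound 1 to compound 3 (1.53 log units; beyond the scatter). Among these compounds, this is the first change at this position read in a single place, and the value for compound 3 is a limit, so the true size of the step remains unknown. Methyl remains the only group here with a numerical value, and the set is now mostly at the ceiling: the limit of > 20000 nM in this assay, at which 2 of the 3 values shown sit.

Going by these compounds, whether ethyl, cyclopropyl or unsubstituted phenyl on this carbonyl carbon keeps a measurable value stays open. So does the effect of a dimethylamino group there.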